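Replacing a Nitrile with a Methylated Tetrazole

The source may hold more compounds than are shown below. What is called first, only, known or untested is meant among the compounds shown, and "the series" means these compounds.

Compound 2 `CCc1cc(C(C)=O)c(O)cc1OCCCCCC(C)(C)C#N` stands second highest among three measured compounds in an assay on isolated protein for binding affinity to leukotriene B4 receptor 1 (Homo sapiens), tested at 1 uM (a higher number here means more inhibition at the concentration tested (going by the name of the read-out), a lower number less inhibition), where compound 2 gives 53%. Compound 1 `CCc1cc(C(C)=O)c(O)cc1OCCCC(C)(C)C#N` gives 46%, and the step of a number 7 percentage points higher from compound 1 to compound 2 (within the scatter). Compound 3 `CCc1cc(C(C)=O)c(O)cc1OCCCC(C)(C)c1nnn[nH]1` gives 76%, and the step of a number 23 percentage points higher from compound 2 to compound 3 (beyond the scatter).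

Compound 4 `CCc1cc(C(C)=O)c(O)cc1OCCCCCC(C)(C)c1nnnn1C` differs from compound 2 in one place: 1-methyl-1H-tetrazol-5-yl in place of cyano on a saturated chain carbon bound to three saturated chain carbons.

The measured step that bears most directly on this change is a number 30 percentage points higher from compound 1 to compound 3 (beyond the scatter). That exchange put 1H-tetrazol-5-yl in place of cyano on the shorter chain of compound 1. In compound 4 the entering group is instead 1-methyl-1H-tetrazol-5-yl, carrying no hydrogen-bond donor, and it sits on the longer chain of compound 2. Among the measured compounds shown here, no measured pair shows exactly this exchange, so the step from compound 1 to compound 3 gives the direction more surely than the size. A rise beyond the scatter is expected, but a more cautious one than the measured step.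

Compound 4 is expected to give 63% in this assay, with a likely range from 45% to 80%. The expected step is a number 10 percentage points higher from compound 2 to compound 4 (within the scatter).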

Compound 4, a percentage reported as inhibition, at one concentration (the size of the read-out at that concentration, not a potency): 59%
Beside the measured number, compound 4's estimate is 4 percentage points above it; measured number inside the range.
By their numbers in this assay, from the lowest: compounds 1, 2 and 4 (each within the scatter of the next, the first and the last beyond it); then compound 3.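

On the longer chain, putting 1-methyl-1H-tetrazol-5-yl in place of cyano gives a number 6 percentage points higher from compound 2 to compound 4 (within the scatter) in this assay, so this saturated chain carbon can carry a five-membered aromatic ring of 6 heavy atoms instead of a 2-atom nitrile with no loss beyond the scatter. This differs from the shorter-chain exchange of cyano for 1H-tetrazol-5-yl, which gave a number 30 percentage points higher from compound 1 to compound 3 (beyond the scatter), and it shows that a tetrazole ring in this place does not always bring a step beyond the scatter. Nothing measured here explains why the two exchanges read differently.

The compounds shown do not separate the two differences between these exchanges, the methyl on the ring and the length of the chain: 1H-tetrazol-5-yl appears only on the shorter chain and 1-methyl-1H-tetrazol-5-yl only on the longer one. Also open, from the compounds shown here alone, is how a carboxylic acid in place of cyano on this same carbon would read in this assay, on either chain.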